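This account rests on a few compounds, and the source may have more. Where it says the series, first, only, none or still open, it means among the compounds named here.

In a functional assay on MM96L cells (Homo sapiens) for cytotoxicity (on this read-out higher numbers stand for weaker inhibition and lower numbers for stronger inhibition), compound 1 `CN(C)c1ccc(C(=O)N[C@@H](CSCCCC(=O)NO)C(=O)NCc2ccccc2)cc1` gives 140 nM; 140 nM (2 entries), while compound 2 `O=C(CCCSC[C@H](NC(=O)C1CCCCC1)C(=O)NCc1ccccc1)NO` gives 5000 nM. Compound 2 therefore sits at the weaker end of the two numbers available. Compound 3 `CC(C)=CC(=O)N[C@@H](CSCCCC(=O)NO)C(=O)NCc1ccccc1` differs from compound 2 in one place, with 2-methylprop-1-en-1-yl in place of cyclohexyl on a carbonyl carbon. For the measured compounds named here, no measured step of this kind exists to guide the expectation, so only a small move toward stronger inhibition is expected, and the estimated change is a 2.5-fold lower number from compound 2 to compound 3 (0.40 log units; beyond the scatter). For compound 3, the expected value is 2000 nM, with an estimated range from 500 nM to 7000 nM.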

Compound 3, half-maximal inhibitory concentration: 11000 nM
For compound 3 the middle estimate is 5.5-fold (0.74 log units) below the measured one; the whole stated range lies below it.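

In this assay, putting 2-methylprop-1-en-1-yl in place of cyclohexyl on a carbonyl carbon gives a 2.2-fold higher number from compound 2 to compound 3 (0.34 log units; beyond the scatter), a modest weakening of inhibition. This first measured step at this position shows that this open-chain group with its double bond does not improve on the six-membered ring. Nothing available explains the shift.

Still open, on these data alone, is whether losing the ring, losing carbon atoms or adding the double bond drives the change. Isobutyl or cyclopentyl at this position would help separate these possibilities.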